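A Chloro Swap on Compound 1

The source may hold more compounds than are shown below. What is called first, only, known or untested is meant among the compounds shown, and "the series" means these compounds.

Measured in a physicochemical assay (Homo sapiens) for solubility, with a stated time of 18 h, at pH 7.4; a lower number here means a less soluble compound, a higher number a more soluble compound:
- compound 1 `CN(C)c1ccc(/C=C2/SC(=Nc3ccccc3)NC2=O)cc1`: 0.1 ug/mL
- compound 2 `CN1CCN(c2ccc(/C=C3/SC(Nc4ccccc4)=NC3=O)cc2)CC1`: 0.35 ug/mL
- compound 3 `O=C1N=C(Nc2ccc(O)cc2)S/C1=C/c1ccc(N2CCNCC2)cc1`: 13.9 ug/mL

Compound 1 stands lowest of the three, clearly under compound 2 and far under compound 3. Compound 4 `CN(C)c1ccc(/C=C2/SC(=Nc3ccccc3Cl)NC2=O)cc1` is not yet measured. It differs from compound 1 in one place, phenyl to 2-chlorophenyl: chloro in place of hydrogen on an aromatic carbon, ortho to a large group (chloro in place of hydrogen on an aromatic carbon).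

Going by the values given here, no measured pair shows this change alone, so the expectation leans on compound 1 at 0.1 ug/mL. In this assay, the expected result is no step beyond the scatter, a 1.3-fold lower number from compound 1 to compound 4 (0.10 log units; within the scatter). For compound 4 the estimated value is 0.08 ug/mL, with an expected range of 0.02 ug/mL to 0.3 ug/mL.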

Compound 4, solubility: 0.02 ug/mL
Compound 4: the middle estimate sits 4.0-fold (0.60 log units) above what was measured; low and high end bracket the measured number.
By their numbers in this assay, from the lowest: compound 4; then compound 1; then compound 2; then compound 3.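

In this assay, going by these compounds alone, the swap of phenyl to 2-chlorophenyl gives a 5.0-fold lower number from compound 1 to compound 4 (0.70 log units; beyond the scatter) and is the first single-place step in this set. It shows that one chloro in place of hydrogen, ortho to a large group, can move the number beyond the usual scatter, even from the low value of compound 1. No measurement here speaks to the reason. Going by these compounds, whether a fluoro, a methoxy or an amine at this position would move the number the same way stays open. So does whether chloro would have the same effect on compound 2.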